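The source may report more compounds than this note shows. Statements on the series, on what has been measured and on what is new or still open speak of the compounds shown alone.

Working notes on the series, step from compound 1 to compound 3.

Going by the values given here, compound 1 `CCOC(=O)CN(C)C(=O)c1ccc(C(CC)(CC)c2ccc(OCC(O)C(C)(C)C)c(C)c2)n1CC` is one of two compounds so far measured in a functional assay on HepG2 cells (Homo sapiens), read by MTT assay, with a stated time of 48 h; a lower number here means a stronger inhibitor, a higher number a weaker inhibitor. For compound 1 the assay gives only a limit, > 50000 nM, and not a number. Compound 2 `CCn1c(C(=O)NCCCN(C)C)ccc1C(CC)(CC)c1ccc(OCC(O)C(C)(C)C)c(C)c1` shares the core and differs only at the amide; in this assay compound 2 gives 360 nM. Among the compounds with values here, the single measured step, an at least 130-fold lower number from compound 1 to compound 2 (2.14 log units; beyond the scatter), is the only evidence on this position, and its size is set by the limit of > 50000 nM in this assay, at which 1 of the 2 values shown sits, so the true size of that step is not known.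

Compound 3 `CCn1c(C(=O)N(CCC#N)CCC#N)ccc1C(CC)(CC)c1ccc(OCC(O)C(C)(C)C)c(C)c1` is the next compound to be measured. It differs from compound 1 as follows: a group of 9 heavy atoms (6 carbon, 3 nitrogen; no ring) in place of a group of 8 heavy atoms (5 carbon, 1 nitrogen, 2 oxygen; no ring), on a carbonyl carbon. Like compound 1, compound 3 keeps a carbonyl carbon bearing a group without a hydrogen-bond donor, while the one measured step brought in a (3-(dimethylamino)propyl)amino group. The measured step therefore bears on the position but not on the group entering. A step of an at least 2.5-fold lower number from compound 1 to compound 3 (0.39 log units; beyond the scatter) is expected, in the direction of a lower number, but smaller than the measured step. Compound 3 is expected to give about 20000 nM, within 3000 nM to 100000 nM, with a real chance that the assay again reports only a limit.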

Compound 3, half-maximal inhibitory concentration: 42000 nM
For compound 3 the middle estimate is 2.1-fold (0.32 log units) below the measured one, and the stated range covers the measured number.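

In this assay, replacing the (3-(dimethylamino)propyl)amino group of compound 2 with the nitrile-bearing group of compound 3 gives a 120-fold higher number from compound 2 to compound 3 (2.07 log units; beyond the scatter), so the large effect at this carbonyl carbon now rests on two measured numbers and not only on a limit. From the compounds shown here alone, the other step, an at least 1.1-fold lower number from compound 1 to compound 3 (0.07 log units; that floor lies within the scatter), does not place the nitrile-bearing group and the ((ethoxycarbonyl)methyl)(methyl)amino group in any order, and its true size stays unknown: the limit of > 50000 nM in this assay, at which 1 of the 3 values shown sits. Compound 1 gives > 50000 nM, which is a limit and not a number.

The compounds shown do not separate the dimethylamino end of the chain in compound 2 from its amide hydrogen, as both change together in the step to compound 3. Also open, going by these compounds, is how this assay would read a shorter (2-(dimethylamino)ethyl)amino group, a chain ending in a morpholine, or a chain of the same length ending in a carboxylic acid.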